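Chloro for trifluoromethoxy on the benzylidene ring

The source may report more compounds than this note shows. Statements on the series, on what has been measured and on what is new or still open speak of the compounds shown alone.

Compound 1 `O=C1/C(=C/c2ccccc2OC(F)(F)F)CCc2ccc(O)cc21` gives 420 nM in a functional assay on RAW264.7 cells (Mus musculus) for inhibition; on this read-out higher numbers stand for weaker inhibition and lower numbers for stronger inhibition. Compound 3 `O=C1/C(=C/c2ccccc2Cl)CCc2ccc(O)cc21` gives 270 nM in this assay, and the step is a 1.6-fold lower number from compound 1 to compound 3 (0.19 log units; within the scatter), the change being (chloro in place of trifluoromethoxy on an aromatic carbon). Compound 2 `O=C1/C(=C/c2ccc(OC(F)(F)F)cc2)CCc2ccc(O)cc21` gives 980 nM in this assay, a higher number than compound 1 and compound 3; the difference between the cores of compound 1 and compound 2 is not broken down here. Compound 4 `O=C1/C(=C/c2ccc(Cl)cc2)CCc2ccc(O)cc21` is not yet measured; it differs from compound 2 by chloro in place of trifluoromethoxy on an aromatic carbon. This is the same kind of change as from compound 1 to compound 3, not the same: there the chloro sits ortho to a large group, here para to a large group. Resting on that single precedent, a step of about a 1.6-fold lower number from compound 2 to compound 4 (0.21 log units; within the scatter) is expected, so compound 4 is estimated at 600 nM in this assay, between 300 nM and 1200 nM.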

Compound 4, half-maximal inhibitory concentration: 1100 nM
For compound 4 the middle estimate is 1.8-fold (0.26 log units) below the measured one; the range from low to high includes it.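

In this assay, chloro in place of trifluoromethoxy gives a 1.1-fold higher number from compound 2 to compound 4 (0.05 log units; within the scatter), so this exchange produces no step beyond the scatter on this core. Set beside the earlier step, the exchange reads alike on both cores: the same change on two cores in this assay, a 1.6-fold lower number (0.19 log units; within the scatter) from compound 1 to compound 3 and a 1.1-fold higher number (0.05 log units; within the scatter) from compound 2 to compound 4, 1.7-fold (0.24 log units) apart, within the scatter of two such steps These two pairs show that the exchange can be carried between these two cores without a clear shift in the number, but they do not show that the two steps are identical or that the same would hold on any other core.

Still open, on these data alone, is whether an amine, a carboxylic acid or a longer chain on the same aromatic carbon would shift the number beyond the scatter. The compounds shown also leave open how the hydroxyl group on the shared core contributes.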